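The source may hold more compounds than are shown below. What is called first, only, known or untested is meant among the compounds shown, and "the series" means these compounds.

Measured so far:
compound 1, `Cc1cn2c(/C=N/NC(=N)N)c(-c3cccnc3)nc2s1`: 6920 nM
compound 2, `N=C(N)N/N=C/c1c(-c2cccnc2)nc2sc(Cl)cn12`: 15100 nM

In a functional assay on prostate cells (Homo sapiens) for antiproliferative activity (on this read-out lower numbers stand for stronger inhibition of growth and higher numbers for weaker inhibition of growth), compound 1 stands lowest of the two numbers; compound 2 sits at 15100 nM, and the step of a 2.2-fold higher number from compound 1 to compound 2 (0.34 log units; beyond the scatter) comes from chloro in place of methyl on an aromatic carbon. Compound 3, `Cc1cn2c(/C=N/NC(=N)N)c(-c3ccccn3)nc2s1`, is not yet measured; it differs from compound 1 by pyridin-2-yl in place of pyridin-3-yl on an aromatic carbon. Within the data shown here, the single measured step concerns a different change and does not bear on this one, so nothing beyond the scatter is expected in this assay, and the range is left wide. The step of a 1.2-fold higher number from compound 1 to compound 3 (0.06 log units; within the scatter) is an estimate only. Compound 3 is expected at 8000 nM, between 2500 nM and 25000 nM.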

Compound 3, concentration for 50% growth inhibition: 7940 nM
For compound 3 the middle estimate is 1.0-fold (0.00 log units) above the measured one, and the stated range covers the measured number.
By their numbers in this assay, from the lowest: compounds 1, 3 and 2 (each within the scatter of the next, the first and the last beyond it).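

Changing from pyridin-3-yl to pyridin-2-yl on this aromatic carbon gives a 1.1-fold higher number from compound 1 to compound 3 (0.06 log units; within the scatter) in this assay and so does not separate the two attachments of the pyridine ring. The earlier pair varied only the other substituent on the shared core and could not show this. No available evidence bears on this result.

Open, going by these compounds, is whether a phenyl ring or a saturated amine such as morpholine at this position would give a number beyond the scatter. Also open, on these data alone, is whether the pyridin-2-yl group behaves the same with chloro in place of methyl.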